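The source may report more compounds than this note shows. Statements on the series, on what has been measured and on what is new or still open speak of the compounds shown alone.

Measured so far:
compound 1 `CC(C)COc1ccc(-c2cn3c(=O)n(-c4ccccc4)nc3c(N)n2)cc1` — in an assay on cells for displacement of a labelled ligand from adenosine receptor A1 (Homo sapiens), read by scintillation counting, with a stated time of 3 h (a higher number here means a weaker inhibitor, a lower number a stronger inhibitor), the result is "not determined" (no result reported)
compound 2 `O=c1[nH]c(-c2ccccc2)cn2c(=O)n(-c3ccccc3)nc12` — in this assay compound 2 gives > 30000 nM, which is a limit of the assay rather than a number

For the measured compounds named here, compound 1 therefore has no number of its own in this assay, and the only other value shown sits at the limit of > 30000 nM in this assay, at which 1 of the 2 values shown sits. Compound 3 `C#CCOc1ccc(-c2cn3c(=O)n(-c4ccccc4)nc3c(N)n2)cc1` differs from compound 1 by ethynyl in place of isopropyl on a saturated chain carbon bound to an oxygen on an aromatic ring. Going by the values given here, with no measured step between two compounds to lean on, the size and direction of this change in this assay cannot be read from the data. Compound 3 is expected to reach about 3000 nM, somewhere between 300 nM and 30000 nM.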

Compound 3, inhibition constant: > 30000 nM
Compound 3: only a limit was reported (the forecaster's own chance of this, stated with the estimate: 40%); at least 10-fold (1.00 log units) between middle value and limit.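

In this assay compound 3 gives > 30000 nM, a limit of the assay and not a number. For the compounds shown here, no step from compound 1 to compound 3 can be read from this. The compounds shown leave open whether changing isobutoxy to propargyloxy alters inhibition at all.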